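Working notes: chain replacement from compound 1 to compound 4

A few compounds are considered here, and "the series" means these few. Any claim that something is new, unique, unknown or untested is made for them only; others in the source may bear on it.

Compound 1 `CC(C)NCC(=O)NCC(=O)N(C)c1ccc(Cl)cc1C(=O)c1ccccc1Cl` is the reference of this small set. For the measured compounds named here, in a functional assay on the whole organism with Mus musculus as the target, in the rotarod test (on this read-out higher numbers stand for an effect only at larger amounts of compound and lower numbers for an effect already at smaller amounts), compound 1 gives 13 mg/kg, the only actual number recorded among the three measured compounds. The remaining entries sit at the limit of > 100 mg/kg in this assay, at which 2 of the 3 values shown sit. In this assay compound 2 `NC(C(=O)NCC(=O)Nc1ccc(Cl)cc1C(=O)c1ccccc1)c1ccccc1` returns a limit rather than a number, > 100 mg/kg. In this assay compound 3 `CN(C(=O)CNC(=O)c1ccccc1)c1ccc(Cl)cc1C(=O)c1ccccc1` also returns a limit rather than a number, > 100 mg/kg. Going by the values given here, no two of these measured compounds differ in a single place, so no measured step exists; the values of compounds 2 and 3 show only that neither produced a number.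

Compound 4 `CCCCC(=O)NCC(=O)N(C)c1ccc(Cl)cc1C(=O)c1ccccc1Cl` has not yet been tested. Relative to compound 1 the change is propyl in place of isopropylamino on a saturated chain carbon bound to a carbonyl carbon. The expectation for compound 4 in this assay is a step towards a larger dose, beyond the usual scatter, of size a 3.1-fold higher number from compound 1 to compound 4 (0.49 log units; beyond the scatter). Compound 4 is therefore estimated at 40 mg/kg, with a range from 12 mg/kg to 150 mg/kg, and a fair chance that only a limit is reported.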

Compound 4, dose for half-maximal effect: 90 mg/kg
Compound 4: the middle estimate sits 2.3-fold (0.35 log units) below what was measured; measured number inside the range.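

In this assay, the first step read at this position, on a saturated chain carbon bound to a carbonyl carbon, is the exchange of isopropylamino for propyl: a 6.9-fold higher number from compound 1 to compound 4 (0.84 log units; beyond the scatter). Compound 4 still gives a number, so a measurable effect in this series does not depend on the nitrogen of isopropylamino, although the dose required rises with its loss. Compound 2 and compound 3 remain limits rather than numbers, so this single step is the only reading of the position: the limit of > 100 mg/kg in this assay, at which 2 of the 4 values shown sit.

The step changes the nitrogen and the chain shape together, so the contribution of each stays unresolved. As far as these compounds go, whether a smaller amine such as methylamino, a cyclic amine such as piperidine, or a carboxylic acid at this position would keep the dose of compound 1 remains open.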